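Trifluoromethyl Replacing Hydrogen on the Aryl Ring

This account rests on a few compounds, and the source may have more. Where it says the series, first, only, none or still open, it means among the compounds named here.

Compound 1 `CCCCOc1cccc(Nc2nc3nonc3nc2O)c1`: 2300 nM
Compound 2 `Oc1nc2nonc2nc1Nc1cccc(S(F)(F)(F)(F)F)c1`: 3700 nM
Compound 3 `Oc1nc2nonc2nc1Nc1ccccc1`: 66700 nM

In an assay on mitochondria from L6 cells (Rattus norvegicus) for activation, with a stated time of 90 min (on this read-out higher numbers stand for an effect only at larger amounts of compound and lower numbers for an effect already at smaller amounts), compound 3 stands highest of the three numbers, its nearest neighbour being compound 2 and its furthest compound 1. Compound 4 `Oc1nc2nonc2nc1Nc1cccc(C(F)(F)F)c1` differs from compound 3 in one place: trifluoromethyl in place of hydrogen on an aromatic carbon. For the measured compounds named here, two measured steps touch this same position, each removing a group there: a 29-fold higher number from compound 1 to compound 3 (1.46 log units; beyond the scatter) and an 18-fold higher number from compound 2 to compound 3 (1.26 log units; beyond the scatter), both large. Compound 4 goes the other way, putting a group back, though one of a different make-up than either butoxy or the sulfur-fluorine group. A lower number is therefore expected for compound 4, with an 8.3-fold lower number from compound 3 to compound 4 (0.92 log units; beyond the scatter) estimated as the likely size. Compound 4 is estimated at 8000 nM, within a range from 3000 nM to 25000 nM.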

Compound 4, half-maximal effective concentration: 13300 nM
Estimate against measurement, compound 4: 1.7-fold (0.22 log units) below, within the range that was stated.
By their numbers in this assay, from the lowest: compounds 1 and 2 (each within the scatter of the next); then compound 4; then compound 3.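

In this assay trifluoromethyl on this aromatic carbon gives back only part of what the other two groups give, with a 5.0-fold lower number from compound 3 to compound 4 (0.70 log units; beyond the scatter) as a modest step. It does not match them, as a 3.6-fold higher number from compound 2 to compound 4 (0.56 log units; beyond the scatter) and a 5.8-fold higher number from compound 1 to compound 4 (0.76 log units; beyond the scatter) both show. Nothing here gives a reason for these differences.

As far as these compounds go, whether a methyl, an amine or a carboxylic acid at this place would stand nearer compound 3 or nearer compounds 1 and 2 stays open. So does whether a chain longer than butoxy would lower the number further.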